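Nucleoside series: azido to benzylsulfanyl on an aromatic carbon

The source may hold more compounds than are shown below. What is called first, only, known or untested is meant among the compounds shown, and "the series" means these compounds.

Measured so far in a functional assay on EL4 cells (Mus musculus) for inhibition, tested at 100 uM; a lower number here means less inhibition, a higher number more inhibition at the concentration tested (going by the name of the read-out):
compound 1 `CCCCCCNc1[nH]ccc2ncnc1-2`, 100%
compound 2 `[N-]=[N+]=Nc1nccc2c1ncn2[C@H]1C[C@H](O)[C@@H](CO)O1`, 13%
compound 3 `CCNc1nccc2c1ncn2C1O[C@H](CO)[C@@H](O)[C@H]1O`, 8%

Compound 2 stands second highest of the three numbers. Its nearest neighbour is compound 3, whose value lies within the scatter of that of compound 2, so the two cannot be ordered. Among the measured compounds shown here, compound 1, the only compound without a sugar, lies far above both, beyond the scatter.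

The next compound, compound 4 `OC[C@H]1O[C@@H](n2cnc3c(SCc4ccccc4)nccc32)C[C@@H]1O`, keeps the sugar of compound 2 and differs from it in one place:

benzylsulfanyl in place of azido on an aromatic carbon

For the measured compounds named here, no step between two measured compounds is available for this change, so its size is unknown. The two sugar-bearing compounds, compound 2 and compound 3, both sit low while differing widely in the group on that aromatic carbon, which gives no sign that a change at this position moves the number far. The expected step from compound 2 to compound 4 is therefore a number 7 percentage points higher from compound 2 to compound 4 (within the scatter), small and not clearly beyond the scatter. Compound 4 is expected to give 20% in this assay, with a range from 5% to 50%.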

Compound 4, a percentage reported as inhibition, at one concentration (the size of the read-out at that concentration, not a potency): 11%
Estimate against measurement, compound 4: 9 percentage points above, within the range that was stated.
By their numbers in this assay, from the lowest: compounds 3, 4 and 2 (each within the scatter of the next); then compound 1.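

In this assay, benzylsulfanyl in place of azido on the aromatic carbon next to the ring nitrogen gives a number 2 percentage points lower from compound 2 to compound 4 (within the scatter), the first step read directly at this position. With the sugar of compound 2 kept, a group with one six-membered aromatic ring of carbon only enters where a group with no ring leaves, and the number does not move beyond the scatter. Nothing available gives a reason for this result.

Open, from the compounds shown here alone, is whether a carboxylic acid or a chlorine atom on this aromatic carbon would move the number with this sugar in place. Also open, going by these compounds, is what the sugar itself contributes, which would take a pair of compounds differing only in the sugar.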